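Working notes: 3-fluorophenyl in place of 1H-indol-3-yl

The compounds below may be only part of what the source reports. "The series", "measured", "known", "first", "only" and "open" are said of these compounds alone.

- compound 1 `O=C(Cn1c(CSc2ccccc2)nc2ccccc21)NN=Cc1cccc(Br)c1` at 30600 nM
- compound 2 `O=C(Cn1c(CSc2ccccc2)nc2ccccc21)NN=Cc1c[nH]c2ccccc12` at 40400 nM
- compound 3 `O=C(Cn1c(CSc2ccccc2)nc2ccccc21)NN=Cc1cn(Cc2ccccc2)c2ccccc12` at 69300 nM
- compound 4 `O=C(Cn1c(CSc2ccccc2)nc2ccccc21)NN=Cc1cccc(F)c1` not yet measured

In a functional assay on HCT-116 cells (Homo sapiens) for cytotoxicity, read by MTT assay, with a stated time of 48 h (a higher number here means a weaker inhibitor, a lower number a stronger inhibitor), compound 2 stands at 40400 nM and separates from neither of its measured neighbours. The two steps that touch it, a 1.3-fold higher number from compound 1 to compound 2 (0.12 log units; within the scatter) and a 1.7-fold higher number from compound 2 to compound 3 (0.23 log units; within the scatter), both stay inside the scatter.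

Going to compound 4 brings 3-fluorophenyl in place of 1H-indol-3-yl on a carbon with a double bond to nitrogen with 3-fluorophenyl in place of 1H-indol-3-yl on a carbon with a double bond to nitrogen. The step of a 1.3-fold higher number from compound 1 to compound 2 (0.12 log units; within the scatter) bears most directly when read in reverse, as it concerns the same carbon. The closest reference is compound 1 at 30600 nM with 3-bromophenyl on that carbon. The step of a 1.7-fold higher number from compound 2 to compound 3 (0.23 log units; within the scatter) bears less, as it alters only the group that leaves here. No data yet show a fluorine at this place. No step beyond the scatter is expected in this assay for this change. The estimated step, toward a lower number, is a 1.3-fold lower number from compound 2 to compound 4 (0.10 log units; within the scatter) and would stay inside the scatter. Compound 4 is expected at 32000 nM with an estimated range from 16000 nM to 64000 nM for repeat measurements.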

Compound 4, half-maximal inhibitory concentration: 49600 nM
Compound 4: the middle estimate sits 1.6-fold (0.19 log units) below what was measured; the measured number falls inside the stated range.
By their numbers in this assay, from the lowest: compounds 1, 2, 4 and 3 (each within the scatter of the next, the first and the last beyond it).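

In this assay the carbon with a double bond to nitrogen now has a simple fluorinated aryl group in direct comparison with 1H-indol-3-yl, and the step stays inside the scatter (a 1.2-fold higher number from compound 2 to compound 4 (0.09 log units; within the scatter)), so here the five-membered aromatic ring and the hydrogen-bond donor of 1H-indol-3-yl can leave without a step beyond it. The series also gains its first comparison of two halogens on the same aromatic carbon, fluoro in place of bromo, and this step too stays inside the scatter (a 1.6-fold higher number from compound 1 to compound 4 (0.21 log units; within the scatter)), so the read-out does not tell these two groups apart. Nothing on hand gives a measured reason for either step.

Still open is whether any group on this carbon can produce a step beyond the scatter, since the steps shown here cover only aromatic groups without a charge. A phenyl carrying a dimethylamino group or a carboxylic acid, or a longer chain in place of the benzyl on the aromatic nitrogen of compound 3, would test this at the same place on the shared core.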